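Methylpyrazole in Place of a Halogenated Phenyl Ring

This account rests on a few compounds, and the source may have more. Where it says the series, first, only, none or still open, it means among the compounds named here.

Compound 1 `COc1ccc(-c2ncnc3c2cnn3CCN2CCCCC2)cc1`: 531 nM
Compound 2 `Cc1cc(F)ccc1-c1ncnc2c1cnn2CCN1CCCCC1`: 48 nM
Compound 3 `Fc1cc(Cl)ccc1-c1ncnc2c1cnn2CCN1CCCCC1`: 112 nM

In an assay on HEK293 cells for displacement of a labelled ligand from Sigma non-opioid intracellular receptor 1 (Homo sapiens), read by scintillation counting, with a stated time of 120 min (a lower number here means a stronger inhibitor, a higher number a weaker inhibitor), compound 3 gives 112 nM, the second highest of the three numbers. The step of a 2.3-fold higher number from compound 2 to compound 3 (0.37 log units; beyond the scatter) is modest, and the step of a 4.7-fold lower number from compound 1 to compound 3 (0.68 log units; beyond the scatter) is modest as well, so compound 3 sits between its two neighbours. Compound 4 `Cn1nccc1-c1ncnc2c1cnn2CCN1CCCCC1` differs from compound 3 in one place: 1-methyl-1H-pyrazol-5-yl in place of 4-chloro-2-fluorophenyl on an aromatic carbon. The measured steps all concern the same position, and each kept a six-membered carbon ring while swapping its substituents: an 11-fold lower number from compound 1 to compound 2 (1.04 log units; beyond the scatter) was large, a 4.7-fold lower number from compound 1 to compound 3 (0.68 log units; beyond the scatter) and a 2.3-fold higher number from compound 2 to compound 3 (0.37 log units; beyond the scatter) were modest. Among the measured compounds shown here, no measured step replaces that ring with a five-membered ring carrying two nitrogen atoms and two hydrogen-bond acceptors, so the comparison is indirect. The weakest measured compound, compound 1, is the one whose ring carries a hydrogen-bond acceptor; a group with two acceptors and fewer heavy atoms is therefore expected to move the number upward, giving an estimated step of a 3.6-fold higher number from compound 3 to compound 4 (0.55 log units; beyond the scatter). Compound 4 is expected to give about 400 nM, within 120 nM to 1500 nM.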

Compound 4, inhibition constant: 41 nM
For compound 4 the middle estimate is 9.8-fold (0.99 log units) above the measured one; the whole stated range lies above it.
By their numbers in this assay, from the lowest: compounds 4 and 2 (each within the scatter of the next); then compound 3; then compound 1.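

At this position a six-membered carbon ring is not needed: in this assay the change to 1-methyl-1H-pyrazol-5-yl gives a 2.7-fold lower number from compound 3 to compound 4 (0.44 log units; beyond the scatter) and also a 13-fold lower number from compound 1 to compound 4 (1.11 log units; beyond the scatter) on the way to a smaller group with no halogen. Measured against the other ortho-substituted phenyl group, the same change gives a 1.2-fold lower number from compound 2 to compound 4 (0.07 log units; within the scatter) so compound 2 and compound 4 cannot be told apart. Hydrogen-bond acceptors in the group at this position therefore do not by themselves go with a high number, as compound 1 alone had suggested.

No measurement here explains why this five-membered ring does so well. Also open, from the compounds shown here alone, is whether the methyl group on the pyrazole matters, and whether a pyridine ring, or an amine or longer chain in place of that methyl, would give a similar number.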